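The compounds below may be only part of what the source reports. "The series", "measured", "known", "first", "only" and "open" are said of these compounds alone.

Three compounds have been measured in an assay on cells for antagonist activity at vitamin D3 receptor (Homo sapiens), read by a luciferase reporter; on this read-out higher numbers stand for weaker inhibition and lower numbers for stronger inhibition:

Compound 1 `COC(=O)c1ccc(OCc2oc(-c3ccccc3OC)nc2C)cc1` gives 17900 nM.
Compound 2 `COC(=O)c1ccc(OCc2oc(-c3cccc(OC)c3)nc2C)cc1` gives 8890 nM.
Compound 3 `COC(=O)CCc1ccc(OCc2oc(-c3ccccc3OC)nc2C)cc1` gives 13600 nM.

Compound 3 holds the second highest of the three numbers. Its nearest neighbour is compound 1, and the step of a 1.3-fold lower number from compound 1 to compound 3 (0.12 log units; within the scatter) stays within the scatter, so nothing separates the two. Among the measured compounds shown here, compound 2 and compound 3 are likewise within the scatter of each other, and no single-point step joins them.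

Compound 4 `COC(=O)CCc1ccc(OCc2oc(-c3cccc(OC)c3)nc2C)cc1` has not been measured. It differs from compound 3 in one place: 3-methoxyphenyl in place of 2-methoxyphenyl on an aromatic carbon. The same exchange has been seen once already, between compound 1 and compound 2, where it gave a 2.0-fold lower number from compound 1 to compound 2 (0.30 log units; within the scatter), a change that does not rise above the scatter. That one precedent is all there is, so the step from compound 3 to compound 4 is expected to be of similar size and direction, a 1.9-fold lower number from compound 3 to compound 4 (0.29 log units; within the scatter), though it may well fall within the scatter. Compound 4 is therefore estimated at 7000 nM, with a plausible range from 3000 nM to 16000 nM.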

Compound 4, half-maximal inhibitory concentration: 6700 nM
For compound 4 the middle estimate is 1.0-fold (0.02 log units) above the measured one, within the range that was stated.
By their numbers in this assay, from the lowest: compounds 4, 2, 3 and 1 (each within the scatter of the next, the first and the last beyond it).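

In this assay, 3-methoxyphenyl in place of 2-methoxyphenyl on the five-membered aromatic ring gives a 2.0-fold lower number from compound 3 to compound 4 (0.31 log units; beyond the scatter), a modest step that now lies beyond the scatter, which the earlier instance of this exchange did not. The exchange also proves repeatable on a second core, with the same direction and size: the same change on two cores in this assay, a 2.0-fold lower number (0.30 log units; within the scatter) from compound 1 to compound 2 and a 2.0-fold lower number (0.31 log units; beyond the scatter) from compound 3 to compound 4, 1.0-fold (0.00 log units) apart, within the scatter of two such steps The side-chain exchange, 2-(methoxycarbonyl)ethyl in place of methoxycarbonyl, gives a 1.3-fold lower number from compound 2 to compound 4 (0.12 log units; within the scatter), which stays within the scatter but likewise repeats: the same change on two cores in this assay, a 1.3-fold lower number (0.12 log units; within the scatter) from compound 1 to compound 3 and a 1.3-fold lower number (0.12 log units; within the scatter) from compound 2 to compound 4, 1.0-fold (0.00 log units) apart, within the scatter of two such steps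

These readings rest on just two pairs for each exchange, and all four compounds carry a methoxyphenyl group and a methoxycarbonyl end. The compounds shown leave open whether an unsubstituted phenyl at this position would follow the same trend, and what a carboxylic acid or a longer chain would do on the other side of the molecule.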